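Compound 4 assessed from three thiazolidinone amides

A few compounds are considered here, and "the series" means these few. Any claim that something is new, unique, unknown or untested is made for them only; others in the source may bear on it.

Measured compounds:
- compound 1, `O=C(NCCCCc1ccccc1)c1cccc(C2SCC(=O)N2c2cccc(F)c2)c1`, 32.4 nM
- compound 2, `C#Cc1cccc(N2C(=O)CSC2c2cccc(C(=O)NCCCCc3ccccc3)c2)c1`, 149 nM
- compound 3, `COc1cc(F)ccc1N1C(=O)CSC1c1cccc(C(=O)NCCCCc2ccccc2)c1`, 71.1 nM

In a functional assay on HOS-TE85 cells (Homo sapiens) for inhibition, read by CCK-8 assay, with a stated time of 72 h (on this read-out higher numbers stand for weaker inhibition and lower numbers for stronger inhibition), compound 3 stands second highest of the three numbers. Its nearest neighbour is compound 2, reached by a 2.1-fold lower number from compound 2 to compound 3 (0.32 log units; beyond the scatter), and the furthest is compound 1, from which compound 3 is separated by a 2.2-fold higher number from compound 1 to compound 3 (0.34 log units; beyond the scatter). Compound 4, `COc1ccc(N2C(=O)CSC2c2cccc(C(=O)NCCCCc3ccccc3)c2)c(OC)c1`, has not yet been measured. It differs from compound 3 by methoxy in place of fluoro on an aromatic carbon, the site being on an aromatic carbon of a six-membered aromatic ring of carbon only, meta to a methoxy group and para to a large group.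

For the measured compounds named here, no measured step exchanges fluoro for methoxy. The closest comparison is a 4.6-fold higher number from compound 1 to compound 2 (0.66 log units; beyond the scatter), where another substituent replaced fluoro on an aromatic carbon and weakened inhibition modestly; the two changes of the aryl group on the ring nitrogen, a 2.2-fold higher number from compound 1 to compound 3 (0.34 log units; beyond the scatter) and a 2.1-fold lower number from compound 2 to compound 3 (0.32 log units; beyond the scatter), were also modest. A modest step is therefore expected for compound 4 in this assay, more likely towards a higher number, estimated as a 1.5-fold higher number from compound 3 to compound 4 (0.17 log units; within the scatter). Compound 4 is expected to give about 105 nM, between 40 nM and 260 nM.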

Compound 4, half-maximal inhibitory concentration: 90.4 nM
Compound 4: middle estimate off by 1.2-fold (0.07 log units), on the high side; the range from low to high includes it.
By their numbers in this assay, from the lowest: compound 1; then compounds 3, 4 and 2 (each within the scatter of the next, the first and the last beyond it).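

In this assay, for the compounds shown here, the first direct exchange of fluoro for methoxy on this aromatic carbon, meta to a methoxy group and para to a large group, gives a 1.3-fold higher number from compound 3 to compound 4 (0.10 log units; within the scatter), so adding one heavy atom and one hydrogen-bond acceptor here does not move the number beyond the scatter. The 2,4-dimethoxyphenyl group likewise cannot be separated from the 3-ethynylphenyl group, with a 1.6-fold lower number from compound 2 to compound 4 (0.22 log units; within the scatter), whereas the change from the 3-fluorophenyl group stays beyond the scatter, with a 2.8-fold higher number from compound 1 to compound 4 (0.45 log units; beyond the scatter), leaving compound 1 as the strongest inhibitor of the four. No measurement is available that would explain these readings.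

The compounds shown leave open whether an amine or a carboxylic acid on this aromatic carbon would keep the number in the same range. They also leave open whether the exchange of fluoro for methoxy would read the same way on an aryl group that lacks the methoxy group which stays in place from compound 3 to compound 4.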